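Trading Methoxy for Chloro in a Cytotoxicity Series

A few compounds are considered here, and "the series" means these few. Any claim that something is new, unique, unknown or untested is made for them only; others in the source may bear on it.

Compound 1 `CNC(=O)c1cc(Oc2ccc(NC(=O)c3cc(-c4ccc(F)cc4)ncn3)cc2F)ccn1` in a functional assay on MCF7 cells (Homo sapiens) for cytotoxicity, read by MTT assay, with a stated time of 72 h (a lower number here means a stronger inhibitor, a higher number a weaker inhibitor), gives > 100000 nM, a limit of the assay.
Compound 2 `CNC(=O)c1cc(Oc2ccc(NC(=O)c3cc(-c4ccc(OC)cc4)ncn3)cc2F)ccn1` gives 46200 nM.
Compound 3 `CNC(=O)c1cc(Oc2ccc(NC(=O)c3nccc(-c4ccc(OC)cc4)n3)cc2F)ccn1` gives > 100000 nM, likewise a limit.

Among the compounds with values here, compound 2 thus holds the only number in this assay; the other two values are limits. The unmeasured compound 4 `CNC(=O)c1cc(Oc2ccc(NC(=O)c3cc(-c4ccc(Cl)cc4)ncn3)cc2F)ccn1` differs from compound 2 by chloro in place of methoxy on an aromatic carbon: methoxy leaves, chloro enters on an aromatic carbon. Within the data shown here, one measured step bears on this, an at least 2.1-fold lower number from compound 1 to compound 2 (0.33 log units; beyond the scatter), where methoxy in place of fluoro moved the value from a limit to a number. Compound 1 carries fluoro at the same place. A step back toward weaker inhibition is therefore expected for compound 4, with a real chance of a limit because of the limit of > 100000 nM in this assay, at which 2 of the 3 values shown sit. Compound 4 is estimated at 90000 nM, between 35000 nM and 250000 nM. The expected step is a 1.9-fold higher number from compound 2 to compound 4 (0.29 log units; within the scatter).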

Compound 4, half-maximal inhibitory concentration: > 100000 nM
Compound 4: only a limit was reported (the forecaster's own chance of this, stated with the estimate: 55%); at least 1.1-fold (0.04 log units) between middle value and limit.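

Chloro in place of methoxy on this aromatic carbon gives an at least 2.1-fold higher number from compound 2 to compound 4 (0.33 log units; beyond the scatter) in this assay, so a second group besides fluoro now fails to hold a number there. Of the three groups placed here on the core of compound 1, only the methoxy of compound 2 gives a number rather than a limit. The step from compound 1 to compound 4 cannot be read, both values being limits, and the same limit recurs across the series: the limit of > 100000 nM in this assay, at which 3 of the 4 values shown sit.

Going by these compounds, how fluoro and chloro rank against each other stays open, as does whether an amine, a hydroxyl or a longer ethoxy chain at this place would give a number in this assay.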